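Removing the 2-Fluorobenzyl Group from Compound 2

This account rests on a few compounds, and the source may have more. Where it says the series, first, only, none or still open, it means among the compounds named here.

Compound 1 `Cc1cc(C)c(S(=O)(=O)N2CCC(N3CCN(C)CC3)CC2)c(C)c1`: > 5000 nM
Compound 2 `Cc1cc(C)c(S(=O)(=O)N2CCC(N3CCC(Cc4ccccc4F)CC3)CC2)c(C)c1`: > 5000 nM

Both compounds were tested in an ADME assay on HCT-116 cells (Homo sapiens) for cytotoxicity, read by CellTiter-Glo, with a stated time of 72 h; a lower number here means a stronger inhibitor, a higher number a weaker inhibitor. In this assay compound 1 reads > 5000 nM, which is a limit of the assay and not a number. In this assay compound 2 reads > 5000 nM, which is also a limit and not a number. Compound 2 therefore stands at the limit of > 5000 nM in this assay, at which 2 of the 2 values shown sit.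

Compound 3 `Cc1cc(C)c(S(=O)(=O)N2CCC(N3CCCCC3)CC2)c(C)c1` has hydrogen in place of 2-fluorobenzyl on a saturated ring carbon, three ring bonds from the ring nitrogen. The counted change is hydrogen in place of 2-fluorobenzyl on a saturated ring carbon.

Among the measured compounds shown here, no measured step between two compounds shows what such a change does, so the expectation rests only on (the limit of > 5000 nM in this assay, at which 2 of the 2 values shown sit). With both measured compounds at that limit, compound 3 is expected to show no clear gain as an inhibitor in this assay, and it will probably also report only a limit. The expected change is a step that the limit leaves unreadable from compound 2 to compound 3, which is none beyond the scatter.

For compound 3 the estimated value is 8000 nM, with an expected range from 4000 nM to 20000 nM.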

Compound 3, half-maximal inhibitory concentration: > 5000 nM
Compound 3 was reported as a limit; the forecaster's own chance of this, stated with the estimate: 85%; the middle value lies beyond the limit too.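

In this assay compound 3 gives > 5000 nM as a limit and not a number. Among the compounds shown here, no step from compound 1 or compound 2 to compound 3 can be read, since all three compounds sit at the same limit: the limit of > 5000 nM in this assay, at which 3 of the 3 values shown sit. The compounds shown leave open whether their true values differ at all in this assay and how far each lies beyond that limit.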